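The source may hold more compounds than are shown below. What is called first, only, known or untested is meant among the compounds shown, and "the series" means these compounds.

Measured so far in a functional assay on SR cells (Homo sapiens) for cytotoxicity, read by sulforhodamine B assay, with a stated time of 48 h, tested at 1 uM; on this read-out higher numbers stand for a weaker effect at the one concentration tested and lower numbers for a stronger effect:
Compound 1 `COc1cc(-c2cc(/C=C/C(=O)c3ccc(N)cc3)[nH]n2)cc(OC)c1OC` gives 14%.
Compound 2 `COc1ccc(C(=O)/C=C/c2cc(-c3cc(OC)c(OC)c(OC)c3)n[nH]2)cc1OC` gives 11%.
Compound 3 `COc1ccc(C(=O)/C=C/c2cc(-c3cc(OC)c(OC)c(OC)c3)n[nH]2)cc1` gives 22%.

Compound 3 has the highest of these three numbers: its gap to compound 1 is within the scatter, while a number 11 percentage points higher from compound 2 to compound 3 (beyond the scatter) is beyond it. Compound 4 `COc1cc(-c2cc(/C=C/C(=O)c3ccc(F)c(F)c3)[nH]n2)cc(OC)c1OC` has not yet been measured. It differs from compound 3 in one place: 3,4-difluorophenyl in place of 4-methoxyphenyl on a carbonyl carbon. For the measured compounds named here, no measured step exchanges one whole ring on the carbonyl carbon for another of this kind. The nearest guides are a number 11 percentage points higher from compound 2 to compound 3 (beyond the scatter) and a number 8 percentage points higher from compound 1 to compound 3 (within the scatter), both small, which give little ground for a large shift. Compound 4 is therefore expected to give 25%, between 10% and 45%. This estimate means an expected a number 3 percentage points higher from compound 3 to compound 4 (within the scatter), not beyond the scatter.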

Compound 4, a percentage reported as activity, at one concentration (the size of the read-out at that concentration, not a potency): 84%
The estimate for compound 4 lay 59 percentage points below the measured number; measured number outside the range, above it.
By their numbers in this assay, from the lowest: compounds 2, 1 and 3 (each within the scatter of the next, the first and the last beyond it); then compound 4.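

In this assay, for the compounds shown here, the ring on the carbonyl carbon matters far more than the earlier compounds suggested: exchanging it for 3,4-difluorophenyl brings a number 62 percentage points higher from compound 3 to compound 4 (beyond the scatter), a number 73 percentage points higher from compound 2 to compound 4 (beyond the scatter) and a number 70 percentage points higher from compound 1 to compound 4 (beyond the scatter), which means a much weaker effect each time. The 4-methoxyphenyl, 3,4-dimethoxyphenyl and 4-aminophenyl rings, by contrast, stay much closer to one another. Nothing available gives a reason for this loss. Still open, from the compounds shown here alone, is whether a plain phenyl, or a ring carrying a single fluorine or a chlorine, would behave like the earlier rings or like compound 4.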